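The source may report more compounds than this note shows. Statements on the series, on what has been measured and on what is new or still open speak of the compounds shown alone.

Measured so far in a functional assay on ileum for antagonist activity at histamine H1 receptor (Cavia porcellus); on this read-out lower numbers stand for tighter binding and higher numbers for weaker binding:

compound 1 `N=C(NCCCc1c[nH]cn1)NCCC(c1ccc(Br)cc1)c1ccccn1` — 120 nM
compound 2 `N=C(NCCCc1c[nH]cn1)NCCC(c1ccc(C(F)(F)F)cc1)c1ccccn1` — 282 nM
compound 3 `N=C(NCCCc1c[nH]cn1)NCCC(c1ccc(F)c(F)c1)c1ccccn1` — 85.1 nM

Compound 3 gives the lowest of the three numbers in this assay. The step of a 1.4-fold lower number from compound 1 to compound 3 (0.15 log units; within the scatter) is within the scatter, so compound 1 and compound 3 cannot be ordered against each other. The step of a 3.3-fold lower number from compound 2 to compound 3 (0.52 log units; beyond the scatter) is beyond the scatter, and compound 2 also sits apart from compound 1 by a 2.4-fold higher number from compound 1 to compound 2 (0.37 log units; beyond the scatter).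

Compound 4 `N=C(NCCCc1c[nH]cn1)NCCC(c1ccc(Cl)c(Cl)c1)c1ccccn1` is not yet measured. It differs from compound 3 in one place: 3,4-dichlorophenyl in place of 3,4-difluorophenyl on a saturated chain carbon bound to an aromatic carbon and a saturated chain carbon.

Among the compounds with values here, no measured step swaps one halogen for another at the same two positions. The nearest guide is that compound 1, with a bromo group on the phenyl ring, and compound 3, with two fluorine substituents, lie within the scatter of each other, while the trifluoromethyl compound 2 is the only one that stands apart. Since two halogenated phenyl variants already sit close together, the expectation for compound 4 is a step of a 1.2-fold higher number from compound 3 to compound 4 (0.07 log units; within the scatter) in this assay, within the scatter, in no firm direction. The estimated value for compound 4 is 100 nM, with a range of 40 nM to 250 nM.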

Compound 4, dissociation constant: 79.4 nM
The estimate for compound 4 lay 1.3-fold (0.10 log units) above the measured number, and the stated range covers the measured number.
By their numbers in this assay, from the lowest: compounds 4, 3 and 1 (each within the scatter of the next); then compound 2.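

Within the data shown here, with 3,4-dichlorophenyl in place of 3,4-difluorophenyl on the saturated chain carbon, this assay gives a 1.1-fold lower number from compound 3 to compound 4 (0.03 log units; within the scatter) and so supplies the first measured step in which the halogen changes while the name pattern of the ring stays 3,4-disubstituted; at this place, the two rings cannot be ordered against each other. Compound 4 also cannot be ordered against the 4-bromophenyl compound, given a 1.5-fold lower number from compound 1 to compound 4 (0.18 log units; within the scatter), whereas a 3.6-fold lower number from compound 2 to compound 4 (0.55 log units; beyond the scatter) is beyond the scatter, so among the four compounds only compound 2, with 4-(trifluoromethyl)phenyl, stands apart from the other three in this read-out. No supporting data accompany these results to explain why the halogen exchange leaves the number within the scatter or why compound 2 stands apart.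

The compounds shown leave open whether the flat response extends beyond halogens, for instance to a 3,4-dimethoxyphenyl or a 4-cyanophenyl ring at this place. They also leave open whether an unsubstituted phenyl or a ring bearing an amine or a carboxylic acid would stay with compounds 1, 3 and 4 or stand apart from them as compound 2 does.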